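Notes on the series: compound 2 to compound 3

The compounds below may be only part of what the source reports. "The series", "measured", "known", "first", "only" and "open" are said of these compounds alone.

In a functional assay on HepG2 cells (Homo sapiens) for antiproliferative activity, read by MTT assay (a lower number here means a stronger inhibitor, a higher number a weaker inhibitor), compound 1 (`CCc1ccccc1-n1cc(COc2ccc(/C=C/C(=O)c3ccc4c(c3O)CCC(C)(C)O4)cc2)nn1`) gives 67800 nM and compound 2 (`Cc1ccc(-n2cc(COc3ccc(/C=C/C(=O)c4ccc5c(c4O)CCC(C)(C)O5)cc3)nn2)cc1Br`) gives 110000 nM, so compound 2 stands level with compound 1. Compound 3 (`CC1(C)CCc2c(ccc(C(=O)/C=C/c3ccc(OCc4cn(Cc5ccc([N+](=O)[O-])cc5)nn4)cc3)c2O)O1`) differs from compound 2 as follows: 4-nitrobenzyl in place of 3-bromo-4-methylphenyl on an aromatic nitrogen. Among the measured compounds shown here, the only measured step, a 1.6-fold higher number from compound 1 to compound 2 (0.21 log units; within the scatter), changes the group on that aromatic nitrogen, but it exchanges one substituted phenyl for another. No 4-nitrobenzyl comparison has been measured. The expected change is a 1.3-fold lower number from compound 2 to compound 3 (0.11 log units; within the scatter), nothing beyond the scatter. For compound 3 the estimate is 85000 nM, with an expected range of 30000 nM to 200000 nM.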

Compound 3, half-maximal inhibitory concentration: 69900 nM
For compound 3 the middle estimate is 1.2-fold (0.08 log units) above the measured one, and the stated range covers the measured number.
By their numbers in this assay, from the lowest: compounds 1, 3 and 2 (each within the scatter of the next).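

In this assay, 4-nitrobenzyl on the aromatic nitrogen, which brings hydrogen-bond acceptors that 3-bromo-4-methylphenyl lacks, gives no change beyond the scatter (a 1.6-fold lower number from compound 2 to compound 3 (0.20 log units; within the scatter)). The same holds against 2-ethylphenyl (a 1.0-fold higher number from compound 1 to compound 3 (0.01 log units; within the scatter)), so all three groups at this position read alike, and the number stays high for each. As far as these compounds go, whether an amine, a carboxylic acid or a longer alkyl chain on that nitrogen would move the number beyond the scatter stays open, as does the reading of plain benzyl. Nothing available explains why these groups read alike.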